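The source may report more compounds than this note shows. Statements on the series, on what has been measured and on what is new or still open speak of the compounds shown alone.

Three analogues of a shared core have so far been measured in a functional assay on MDA-MB-231 cells (Homo sapiens) for antiproliferative activity, read by MTT assay, with a stated time of 72 h; a lower number here means a stronger inhibitor, a higher number a weaker inhibitor. Compound 1 `NC1=NC2(CCSCC2)N(OCCCOc2ccc(Cl)cc2)C(N)=N1` gives 350 nM in this assay. Compound 2 `NC1=NC2(CCSCC2)N(OCCCOc2ccccc2Cl)C(N)=N1` gives 80 nM, and compound 3 `NC1=NC2(CCSCC2)N(OCCCOc2ccccc2Br)C(N)=N1` gives 10 nM. Compound 3 thus stands lowest of the three numbers: the steps to it were an 8.0-fold lower number from compound 2 to compound 3 (0.90 log units; beyond the scatter) and a 35-fold lower number from compound 1 to compound 3 (1.54 log units; beyond the scatter), both beyond the scatter.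

The next step leads to compound 4 `NC1=NC2(CCSCC2)N(OCCCOc2cccc(Br)c2)C(N)=N1`, which differs from compound 3 by 3-bromophenyl in place of 2-bromophenyl on an oxygen on a saturated carbon. Among the compounds with values here, no measured pair moves a halogen between these two positions of the phenyl, so the bearing of earlier steps is indirect. Moving the halogen between the other two positions gave a 4.4-fold lower number from compound 1 to compound 2 (0.64 log units; beyond the scatter), and with bromine in the group that leaves the number fell further, a 35-fold lower number from compound 1 to compound 3 (1.54 log units; beyond the scatter). Within the data shown here, since compound 3 is the lowest number so far, a move of the bromine away from its place in compound 3 is expected to raise the number somewhat, though likely less than the full span seen between compounds 1 and 3. Compound 4 is therefore estimated at 40 nM, between 10 nM and 160 nM, a step of a 4.0-fold higher number from compound 3 to compound 4 (0.60 log units; beyond the scatter).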

Compound 4, half-maximal inhibitory concentration: 60 nM
Beside the measured number, compound 4's estimate is 1.5-fold (0.18 log units) below it, within the range that was stated.
By their numbers in this assay, from the lowest: compound 3; then compounds 4 and 2 (each within the scatter of the next); then compound 1.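

Moving the bromine alone, with the same atoms joined differently, changes the number in this assay (a 6.0-fold higher number from compound 3 to compound 4 (0.78 log units; beyond the scatter)), so at this position the place of the halogen matters as well as its identity. The advantage that 2-bromophenyl held over 2-chlorophenyl does not carry over to 3-bromophenyl (a 1.3-fold lower number from compound 2 to compound 4 (0.12 log units; within the scatter)), a step within the scatter, although compound 4 still stands clear of the 4-chlorophenyl compound (a 5.8-fold lower number from compound 1 to compound 4 (0.77 log units; beyond the scatter)). Nothing available explains why the place of the bromine counts for so much.

The compounds shown leave open whether the chloro counterpart of compound 4 would stand level with it, which would test whether the halogen still matters in this place. They also leave open whether a fluoro or methoxy group could replace the bromine of compound 3 and keep its number.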